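The source may report more compounds than this note shows. Statements on the series, on what has been measured and on what is new or still open speak of the compounds shown alone.

For the measured compounds named here, in a functional assay (aorta) for inhibition, with Rattus norvegicus as the target (on this read-out lower numbers stand for stronger inhibition and higher numbers for weaker inhibition), compound 2 `C/N=C(\S)[C@]1(c2ccccc2)CCCC[S+]1[O-]` gives 9500 nM, the higher of the two numbers so far, while compound 1 `C/N=C(\S)[C@]1(c2ccc(Cl)cc2)CCCC[S+]1[O-]` gives 2800 nM. Compound 3 `C/N=C(\S)[C@]1(c2ccc(-c3ccccc3)cc2)CCCC[S+]1[O-]` differs from compound 2 by one change: phenyl in place of hydrogen on an aromatic carbon. Going by the values given here, the one measured step that bears on this is a 3.4-fold higher number from compound 1 to compound 2 (0.53 log units; beyond the scatter), a modest step beyond the scatter, where hydrogen takes the place of chloro on an aromatic carbon. Phenyl replaces that same hydrogen, so a modest fall in the number is expected, though no group this large has been measured. The expected step is a 3.2-fold lower number from compound 2 to compound 3 (0.50 log units; beyond the scatter). Compound 3 is estimated at 3000 nM, within a range of 700 nM to 12000 nM.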

Compound 3, concentration for 90% inhibition: 12000 nM
For compound 3 the middle estimate is 4.0-fold (0.60 log units) below the measured one; the measured number falls inside the stated range.
By their numbers in this assay, from the lowest: compound 1; then compounds 2 and 3 (each within the scatter of the next).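

On the aromatic carbon para to a large group, phenyl and hydrogen cannot be told apart in this assay: the result is a 1.3-fold higher number from compound 2 to compound 3 (0.10 log units; within the scatter). The benefit of chloro therefore does not carry over to this larger group, as replacing chloro with phenyl gives a 4.3-fold higher number from compound 1 to compound 3 (0.63 log units; beyond the scatter). Nothing measured here explains why these two groups differ. The compounds shown leave open whether a smaller atom such as fluorine, or a methyl, methoxy or amine group, would behave like chloro or like hydrogen at this position.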